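Losing the 1,3-thiazol-2-yl group on a sulfonamide nitrogen

A few compounds are considered here, and "the series" means these few. Any claim that something is new, unique, unknown or untested is made for them only; others in the source may bear on it.

Compound 1 (`O=S(=O)(Nc1nccs1)c1ccc(Nc2nncc3ccccc23)cc1`): 55 nM
Compound 2 (`COc1ccc(NC(=S)NNc2nncc3ccccc23)cc1`): 60 nM

Both compounds were tested in a functional assay on MCF7 cells (Homo sapiens) for antiproliferative activity, read by sulforhodamine B assay, with a stated time of 72 h; on this read-out higher numbers stand for weaker inhibition and lower numbers for stronger inhibition. Compound 1 gives 55 nM and compound 2 gives 60 nM, and these two values lie within the usual scatter of each other, so neither compound can be ranked above the other. Compound 3 (`NS(=O)(=O)c1ccc(Nc2nncc3ccccc23)cc1`) has not yet been measured. It has hydrogen in place of 1,3-thiazol-2-yl on a sulfonamide nitrogen. Going by the values given here, no measured pair of compounds shows what a single change of this kind does in this assay, so the expectation is tentative. A moderate step toward a higher number, meaning weaker inhibition, is expected, estimated as a 2.2-fold higher number from compound 1 to compound 3 (0.34 log units; beyond the scatter). The estimated value for compound 3 is 120 nM, with an expected range from 30 nM to 500 nM.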

Compound 3, half-maximal inhibitory concentration: 37 nM
Compound 3: the middle estimate sits 3.2-fold (0.51 log units) above what was measured; the range from low to high includes it.
By their numbers in this assay, from the lowest: compounds 3, 1 and 2 (each within the scatter of the next).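

In this assay, going by these compounds alone, hydrogen in place of 1,3-thiazol-2-yl on a sulfonamide nitrogen gives a 1.5-fold lower number from compound 1 to compound 3 (0.17 log units; within the scatter), the first single change that can be read. The two compounds therefore cannot be told apart, which shows that the whole 1,3-thiazol-2-yl ring can go from this nitrogen without a measurable loss in this read-out. No measurement on hand offers an explanation for this result.

From the compounds shown here alone, it remains open whether a small group such as methyl or acetyl on this nitrogen, or a six-membered ring such as pyridin-2-yl, would leave the number equally unchanged. Also open, going by these compounds, is what happens when the sulfonamide itself gives way to a carboxylic acid or a carboxamide.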